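The source may report more compounds than this note shows. Statements on the series, on what has been measured and on what is new or still open speak of the compounds shown alone.

Measured in a functional assay on Jurkat cells (Homo sapiens) for antiproliferative activity, read by MTT assay; a higher number here means a weaker inhibitor, a lower number a stronger inhibitor:
Compound 1 `COc1cccc(/C=C2\CCc3cc(OC)c(OC)cc3C2=O)c1` gives 5000 nM.
Compound 2 `COc1cc2c(cc1OC)C(=O)/C(=C/c1cccc([N+](=O)[O-])c1)CC2` gives 9000 nM.
Compound 3 `COc1cc2c(c([N+](=O)[O-])c1OC)C(=O)/C(=C/c1cc(C)c(O)c(C)c1)C2` gives only a limit of the assay, > 50000 nM.

Compound 1 and compound 2 share one core; compound 1 carries methoxy in place of nitro on an aromatic carbon. That step, a 1.8-fold lower number from compound 2 to compound 1 (0.26 log units; within the scatter), leaves the two within the usual scatter of each other. The core of compound 3 differs from that of compound 2, but the difference between the two cores is not broken down here. Compound 4 `COc1cc2c(c(OC)c1OC)C(=O)/C(=C/c1cc(C)c(O)c(C)c1)C2`, not yet measured, carries the same kind of change from compound 3: methoxy in place of nitro on an aromatic carbon. The surroundings differ: in compound 3 the place is ortho to a fused ring, ortho to a methoxy group, meta to a fused ring and meta to a methoxy group, whereas in compound 2 it is meta to a large group. Because compound 3 sits at the limit of > 50000 nM in this assay, at which 1 of the 3 values shown sits, the starting point is only a limit. The expected step, an at least 1.6-fold lower number from compound 3 to compound 4 (0.22 log units; that floor lies within the scatter), is taken to be about as small as the measured one. Compound 4 is therefore expected to give roughly 30000 nM in this assay.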

Compound 4, half-maximal inhibitory concentration: 125 nM
Compound 4: middle estimate off by 240-fold (2.38 log units), on the high side, outside the stated range (below it).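

In this assay, methoxy in place of nitro gives an at least 400-fold lower number from compound 3 to compound 4 (2.60 log units; beyond the scatter), and this step does not match the one seen on the other core: the same change on two cores in this assay, a 1.8-fold lower number (0.26 log units; within the scatter) from compound 2 to compound 1 and an at least 400-fold lower number (2.60 log units; beyond the scatter) from compound 3 to compound 4, at least 220-fold (2.34 log units) apart, beyond the scatter of two such steps The value of compound 3 is only a limit of the assay: the limit of > 50000 nM in this assay, at which 1 of the 4 values shown sits. So the size of this change on one core does not predict its size on the other, but these two pairs do not show which difference between the cores matters, and they give no rule for the series.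

From the compounds shown here alone, it remains open whether a different group at this place on the core of compound 4, such as an amine or a chlorine, would give a similar value to methoxy. Going by these compounds, it is also open how large the step would be on other cores.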